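Amino in place of chloro: what to expect for compound 4

The source may hold more compounds than are shown below. What is called first, only, known or untested is meant among the compounds shown, and "the series" means these compounds.

Three members of the series have been tested in a functional assay on UACC-257 cells (Homo sapiens) for cytotoxicity, read by sulforhodamine B assay, with a stated time of 48 h; on this read-out higher numbers stand for weaker inhibition of growth and lower numbers for stronger inhibition of growth. Compound 1 `ClCc1ccccc1Cn1cnc2c(Cl)nc(Cl)nc21` gives 3890 nM in this assay. Compound 2 `ClCc1cccc(Cn2cnc3c(Cl)nc(Cl)nc32)c1` is built from the same atoms joined differently; the difference between the two cores is not broken down here. In this assay compound 2 gives 3460 nM, a value that sits within the scatter of the number for compound 1, so no order between the two is read from it. Compound 3 `Nc1nc(Cl)c2ncn(Cc3ccccc3CCl)c2n1` differs from compound 1 in one place: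

amino in place of chloro on an aromatic carbon

In this assay compound 3 gives 38000 nM, and the step is a 9.8-fold higher number from compound 1 to compound 3 (0.99 log units; beyond the scatter).

Compound 4 `Nc1nc(Cl)c2ncn(Cc3cccc(CCl)c3)c2n1` has not yet been measured. It stands to compound 2 as compound 3 stands to compound 1:

amino in place of chloro on an aromatic carbon

The surroundings of the exchanged group read the same word for word in both cases, so this is taken as the same change, seen two times among the compounds shown. Compound 4 is expected to give about 34000 nM in this assay, with a plausible range from 14000 nM to 85000 nM. Among the measured compounds shown here, this expectation rests on the value of compound 2, 3460 nM, and on the step of a 9.8-fold higher number from compound 1 to compound 3 (0.99 log units; beyond the scatter); the expected step of a 9.8-fold higher number from compound 2 to compound 4 (0.99 log units; beyond the scatter) is estimated to be of the same size as that earlier one, since only a single precedent is available and nothing shows whether the change behaves differently on the core of compound 2.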

Compound 4, concentration for total growth inhibition: 19500 nM
Beside the measured number, compound 4's estimate is 1.7-fold (0.24 log units) above it; low and high end bracket the measured number.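

In this assay, amino in place of chloro gives a 5.6-fold higher number from compound 2 to compound 4 (0.75 log units; beyond the scatter), so the step seen on the core of compound 1 recurs in the same direction on the core of compound 2. Among the compounds shown here, the two steps can be read as one effect of the change, with no difference between the cores resolved: the same change on two cores in this assay, a 9.8-fold higher number (0.99 log units; beyond the scatter) from compound 1 to compound 3 and a 5.6-fold higher number (0.75 log units; beyond the scatter) from compound 2 to compound 4, 1.7-fold (0.24 log units) apart, within the scatter of two such steps This shows that the change carries over between these two cores, but it rests on only two pairs in one assay, so it does not establish that the step would hold on any further core, and it gives no reason for the step.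

The compounds shown leave open whether a methylamino or a methoxy group at the same place would behave like amino. They also leave open whether the step survives when the chloromethyl group is replaced by a methyl group.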